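The source may report more compounds than this note shows. Statements on the series, on what has been measured and on what is new or still open speak of the compounds shown alone.

Measured compounds in a functional assay on HCT-15 cells (Homo sapiens) for cytotoxicity, read by CCK-8 assay and cell counting, with a stated time of 2 days; a higher number here means a weaker inhibitor, a lower number a stronger inhibitor:
compound 1 `Oc1cccc(-c2cc(-c3ccc(Cl)cc3)nc(-c3cccs3)c2)c1` gives 9280 nM
compound 2 `Oc1cccc(-c2cc(-c3cccc(Cl)c3)nc(-c3ccccn3)c2)c1` gives "not determined" (no result reported)
compound 3 `Oc1cccc(-c2cc(-c3ccc(Cl)cc3)nc(-c3ccsc3)c2)c1` gives 8850 nM

Compound 3 holds the lower of the two numbers, with compound 1 nearest; the exchange of thiophene isomers, a 1.0-fold lower number from compound 1 to compound 3 (0.02 log units; within the scatter), lies within the scatter, so the two compounds cannot be ordered. Compound 2 differs from compound 3 in two places and has no number, so it contributes nothing to the comparison.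

Compound 4 `Oc1cccc(-c2cc(-c3ccc(Cl)cc3)nc(-c3ccccn3)c2)c1` is compound 3 with pyridin-2-yl in place of thiophen-3-yl on an aromatic carbon. For the measured compounds named here, only one measured step exists, a 1.0-fold lower number from compound 1 to compound 3 (0.02 log units; within the scatter), and it concerns a shift within the thiophene ring rather than a change of ring type; no measured step bears on a pyridin-2-yl group, and compound 2, the only other entry carrying one, gives no number. The step to compound 4 is therefore expected to stay within the scatter, a 1.0-fold higher number from compound 3 to compound 4 (0.01 log units; within the scatter), with wide uncertainty. For compound 4 the estimate in this assay is 9000 nM, range 3000 nM to 27000 nM.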

Compound 4, half-maximal inhibitory concentration: 13500 nM
Beside the measured number, compound 4's estimate is 1.5-fold (0.18 log units) below it, and the stated range covers the measured number.
By their numbers in this assay, from the lowest: compounds 3, 1 and 4 (each within the scatter of the next).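

In this assay, the earlier pair moved the attachment point within a thiophene; the group next to the ring nitrogen now also changes from a five-membered to a six-membered aromatic ring. Pyridin-2-yl in place of thiophen-3-yl is a 1.5-fold higher number from compound 3 to compound 4 (0.18 log units; within the scatter), and pyridin-2-yl in place of thiophen-2-yl is a 1.5-fold higher number from compound 1 to compound 4 (0.16 log units; within the scatter), so the thiophen-2-yl, thiophen-3-yl and pyridin-2-yl groups cannot be ordered at this position. No supporting data accompany these numbers to account for them.

From the compounds shown here alone, whether an amine, a carboxylic acid or a longer alkyl chain at this position would move the number beyond the scatter remains open. Compound 2 differs from compound 4 in the chlorophenyl group, but that step cannot be read, leaving the effect of the chlorine's placement open as well.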